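Amide group changes and cell toxicity across the series

The source may report more compounds than this note shows. Statements on the series, on what has been measured and on what is new or still open speak of the compounds shown alone.

Measured compounds in a toxicity assay on THP-1 cells (Homo sapiens) for inhibition; on this read-out lower numbers stand for higher toxicity in this test and higher numbers for lower toxicity in this test:
Compound 1 `COc1ccc(-c2cnc(NC(=O)c3cccc(Br)c3)n2C)cc1` gives > 100000 nM, a limit of the assay.
Compound 2 `COc1ccc(-c2cnc(NC(=O)c3cnco3)n2C)cc1` gives > 100000 nM, a limit of the assay.
Compound 3 `CCC(=O)Nc1ncc(-c2ccc(OC)cc2)n1C` gives > 100000 nM, a limit of the assay.

Compound 3 stands only at a limit in this assay, with no number behind it. The same holds for all values shown, since the limit of > 100000 nM in this assay, at which 3 of the 3 values shown sit, describes where every measured compound sits. For this reason the steps a step that the two limits leave unreadable from compound 1 to compound 3, a step that the two limits leave unreadable from compound 2 to compound 3 and a step that the two limits leave unreadable from compound 1 to compound 2 are unreadable in size, and nothing can be said about whether they lie within or beyond the scatter.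

Compound 4 `COc1ccc(-c2cnc(NC(=O)c3ccc(Br)cc3)n2C)cc1` is the next compound to be measured. Its difference from compound 3 is 4-bromophenyl in place of ethyl on a carbonyl carbon. The closest measured change is the step from a bromophenyl amide to the ethyl amide, the unreadable a step that the two limits leave unreadable from compound 1 to compound 3, which gives no size and no direction to work from. Compound 1 with its 3-bromophenyl group and compound 3 with its ethyl group both rest at the limit, so the expectation for compound 4 is that it too sits at the limit, with the estimated step that the limit leaves unreadable from compound 3 to compound 4 carrying no real information. The estimate for compound 4 in this assay is 150000 nM, in the range 50000 nM to 500000 nM.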

Compound 4, half-maximal cytotoxic concentration: > 100000 nM
Compound 4: only a limit was reported; the forecaster's own chance of this, stated with the estimate: 85%; the middle value is on the limit's open side.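

No new step can be read: the steps from compound 1, compound 2 and compound 3 to compound 4 all stay unreadable in size, because all four compounds rest at one limit: the limit of > 100000 nM in this assay, at which 4 of the 4 values shown sit.

The compounds shown leave open whether any of these amide groups on the shared core changes the result in this assay, and in which direction.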